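The source may hold more compounds than are shown below. What is called first, only, known or untested is meant among the compounds shown, and "the series" means these compounds.

Measured in a functional assay on HL-60 cells (Homo sapiens) for inhibition, read by MTT assay, with a stated time of 48 h, tested at 10 uM; a higher number here means more inhibition of growth at the concentration tested, a lower number less inhibition of growth:
Compound 1 `Cc1cc(=O)c2c(O)cc(OCc3ccc([N+](=O)[O-])cc3)c([C@H]3CCN(C)C[C@H]3O)c2o1`: 14%
Compound 2 `Cc1cc(=O)c2c(O)cc(O)c([C@H]3CCN(C)C[C@H]3OC(=O)c3ccco3)c2o1`: 22%
Compound 3 `Cc1cc(=O)c2c(O)c(CN3CCCC3CO)c(O)c([C@H]3CCN(C)C[C@H]3O)c2o1`: 33%

Of these three numbers, compound 3 has the highest, and its gaps to compound 2 and to compound 1 both lie beyond the usual scatter of this kind of measurement. At a single test concentration, the number shows how much cell growth is held back, and it leaves most of the growth untouched for all three compounds.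

The next compound, compound 4 `Cc1cc(=O)c2c(O)c(CN3CCCCC3)c(O)c([C@H]3CCN(C)C[C@H]3O)c2o1`, changes one group of compound 3: piperidin-1-yl in place of 2-(hydroxymethyl)pyrrolidin-1-yl on a saturated chain carbon bound to an aromatic carbon. For the measured compounds named here, compound 1 and compound 2 carry neither group, and no two measured compounds differ in only one place. The data therefore contain no direct measure of this swap.

With compound 3 at 33% as the closest measured structure, the expectation in this assay is a small step, none beyond the scatter, with no firm direction. The expected change is a number 2 percentage points lower from compound 3 to compound 4 (within the scatter). For compound 4 the estimated value is 31%, with an expected range from 15% to 50%.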

Compound 4, percent growth inhibition at one concentration: 32%
The estimate for compound 4 lay 1 percentage points below the measured number, within the range that was stated.
By their numbers in this assay, from the lowest: compounds 1, 2, 4 and 3 (each within the scatter of the next, the first and the last beyond it).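

In this assay, for the compounds shown here, the swap of 2-(hydroxymethyl)pyrrolidin-1-yl for piperidin-1-yl gives the first direct reading of a change on this saturated chain carbon bound to an aromatic carbon: a number 1 percentage points lower from compound 3 to compound 4 (within the scatter). The entering group has no oxygen and no hydrogen-bond donor, yet compound 3 and compound 4 stay within the scatter of each other, so for this one pair, neither the hydroxymethyl group nor the five-membered ring in place of a six-membered one is needed to keep the number where it stands. No measurement available here offers an explanation for this result.

On these data alone, it remains open whether other amines at this place, such as morpholin-4-yl or dimethylamino, or a piperidin-1-yl ring carrying a carboxylic acid, would also stay within the scatter of these two compounds or would shift the number clearly. The single test concentration also leaves open whether compound 3 and compound 4 would still match at other concentrations, and whether this match would hold for the same change on a different core.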